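This account rests on a few compounds, and the source may have more. Where it says the series, first, only, none or still open, it means among the compounds named here.

Working notes on the series. Among the measured compounds shown here, compound 2 `Cc1cc(C)cc(C(=O)c2cc(Cl)ccc2Oc2nc(Nc3ccc(C#N)cc3)ncc2C)c1` is the one member with a number in an ADME assay on MT4 cells (Homo sapiens) for cytotoxicity, read by MTT assay, with a stated time of 5 days; on this read-out higher numbers stand for lower toxicity in this test and lower numbers for higher toxicity in this test: compound 2 gives 13400 nM. Compound 1 `Cc1ccc(C(=O)c2cc(Cl)ccc2Oc2nc(Nc3ccc(C#N)cc3)ncc2C)cc1` carries 4-methylphenyl on the carbonyl carbon where compound 2 carries 3,5-dimethylphenyl. In this assay compound 1 returns only a limit, >= 830 nM. The record shows (the limit of >= 830 nM in this assay, at which 1 of the 2 values shown sits), so the step that the limit leaves unreadable from compound 1 to compound 2 cannot be sized or given a direction. Compound 3 `Cc1ccccc1C(=O)c1cc(Cl)ccc1Oc1nc(Nc2ccc(C#N)cc2)ncc1C` differs from compound 2 by 2-methylphenyl in place of 3,5-dimethylphenyl on a carbonyl carbon. For the measured compounds named here, no measured step in this assay reads on that change; the single exchange at the same carbonyl carbon left no usable size. The working expectation is a step of no change at the digits printed from compound 2 to compound 3 (within the scatter) that stays within the scatter, with no direction asserted. Compound 3 is therefore expected in this assay at about 13400 nM, with a range from 4000 nM to 45000 nM.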

Compound 3, half-maximal cytotoxic concentration: 24200 nM
Estimate against measurement, compound 3: 1.8-fold (0.26 log units) below; low and high end bracket the measured number.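

In this assay, the exchange on the carbonyl carbon now has its first readable size: 2-methylphenyl in place of 3,5-dimethylphenyl reads as a 1.8-fold higher number from compound 2 to compound 3 (0.26 log units; within the scatter). This position therefore accepts these two methyl-bearing phenyl groups with no difference in this read-out beyond the scatter, although the number and placement of the methyl groups differ. Compound 1 still returns only a limit, so the steps linking it to compound 2 and compound 3 cannot be read: the limit of >= 830 nM in this assay, at which 1 of the 3 values shown sits.

Going by these compounds, it remains open where 4-methylphenyl stands relative to 2-methylphenyl and 3,5-dimethylphenyl in this read-out. The compounds shown also leave open whether the same picture would hold with an amine, a carboxylic acid or a longer alkyl chain on the carbonyl carbon.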